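A second phenyl variant on the ring amine nitrogen

A few compounds are considered here, and "the series" means these few. Any claim that something is new, unique, unknown or untested is made for them only; others in the source may bear on it.

Compound 1, `Nc1scc(CN2CCN(C3CCCCCC3)CC2)c1C(=O)c1ccc(Cl)cc1`: 13%
Compound 2, `Nc1scc(CN2CCN(c3c(F)cc(F)cc3F)CC2)c1C(=O)c1ccc(Cl)cc1`: -3.9%

Among the compounds with values here, in a functional assay on CHO cells with adenosine receptor A1 (Homo sapiens) as the target, read by cAMP accumulation and immunoassay, with a stated time of 6 min, tested at 0.1 uM (a higher number here means a weaker effect of the compound at the concentration tested, a lower number a stronger effect), compound 2 gives -3.9%, the lowest of the two numbers so far; the nearest is compound 1, and the step of a number 16.9 percentage points lower from compound 1 to compound 2 (beyond the scatter) is a modest one, beyond the scatter. Compound 3, `Nc1scc(CN2CCN(c3ccc(Cl)c(Cl)c3)CC2)c1C(=O)c1ccc(Cl)cc1`, has not yet been measured. It differs from compound 2 by 3,4-dichlorophenyl in place of 2,4,6-trifluorophenyl on an amine nitrogen in a ring.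

Within the data shown here, only one measured step exists, a number 16.9 percentage points lower from compound 1 to compound 2 (beyond the scatter), and it exchanged a cycloheptyl for a 2,4,6-trifluorophenyl on the same nitrogen. Among the measured compounds shown here, no measured pair compares one phenyl group with another on that nitrogen, so that step bears on the present change only indirectly. With nothing to point either way, the step of a number 5.9 percentage points higher from compound 2 to compound 3 (within the scatter) is expected to stay within the scatter. Compound 3 is therefore estimated at 2%, with a range from -14% to 18%.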

Compound 3, a percentage reported as activity, at one concentration (the size of the read-out at that concentration, not a potency): -13%
Beside the measured number, compound 3's estimate is 15 percentage points above it; low and high end bracket the measured number.
By their numbers in this assay, from the lowest: compounds 3 and 2 (each within the scatter of the next); then compound 1.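

In this assay the exchange of 2,4,6-trifluorophenyl for 3,4-dichlorophenyl on the ring amine nitrogen gives a number 9.1 percentage points lower from compound 2 to compound 3 (within the scatter) and so does not separate these two substituted phenyl groups, although they carry different halogens at different ring positions. Set against cycloheptyl, 3,4-dichlorophenyl gives a number 26 percentage points lower from compound 1 to compound 3 (beyond the scatter) and thus joins 2,4,6-trifluorophenyl in lying on the same side of compound 1, so among these three compounds the separation runs between the cycloheptyl group and the two phenyl groups. Nothing measured alongside these numbers accounts for this result.

Going by these compounds, it remains open whether an unsubstituted phenyl, a pyridyl or a benzyl group on this nitrogen would fall with the two halogenated phenyl groups or with cycloheptyl. A cyclohexyl group could likewise show whether the cycloheptyl result extends to a smaller saturated ring.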